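Replacing chlorine with an amine on the open-chain side group

A few compounds are considered here, and "the series" means these few. Any claim that something is new, unique, unknown or untested is made for them only; others in the source may bear on it.

The series shares a decyl-substituted aryl core joined to a five-membered heteroaromatic ring, and varies only in the group on that ring. Compound 1, `CCCCCCCCCCc1ccc(-c2noc([C@H]3CCC[C@@H](N)C3)n2)cc1`, carries a cyclic diamine on that position and gives 29% in an assay on HeLa cells for inhibition of sphingosine-1-phosphate transporter SPNS2 (Mus musculus), read by LC-MS, tested at 2 uM; on this read-out higher numbers stand for more inhibition at the one concentration tested (going by the name of the read-out) and lower numbers for less inhibition. Among the measured compounds shown here, compound 2, `CCCCCCCCCCc1ccc(-c2noc(C(Cl)CCN)n2)cc1`, gives 5% in this assay and stands lowest of the two numbers so far; the only step on record, a number 24 percentage points lower from compound 1 to compound 2 (beyond the scatter), describes the change from the ring-bearing group to the open chain with chlorine.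

Compound 3, `CCCCCCCCCCc1ccc(-c2noc([C@@H](N)CCN)n2)cc1`, differs from compound 2 by a group of 5 heavy atoms (3 carbon, 2 nitrogen; no ring) in place of a group of 5 heavy atoms (3 carbon, 1 nitrogen, 1 chlorine; no ring), on an aromatic carbon. For the measured compounds named here, no measured step covers an exchange of chlorine for a nitrogen within the open chain, so the one step available bears only indirectly: it shows that the move away from the amine-bearing ring cost inhibition, and compound 3 restores a second amine in an open chain that carries a 1,3-diamine arrangement. On that basis a modest rise in this assay is expected, a number 13 percentage points higher from compound 2 to compound 3 (beyond the scatter), without reaching compound 1. Compound 3 is estimated at 18%, with a range from 0% to 40%.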

Compound 3, a percentage reported as inhibition, at one concentration (the size of the read-out at that concentration, not a potency): 14%
For compound 3 the middle estimate is 4 percentage points above the measured one; low and high end bracket the measured number.
By their numbers in this assay, from the lowest: compounds 2 and 3 (each within the scatter of the next); then compound 1.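

In this assay, 1,3-diaminopropyl in place of the chlorine-bearing open chain gives a number 9 percentage points higher from compound 2 to compound 3 (within the scatter) and so does not set compound 3 apart from compound 2: a second amine in place of chlorine on this open chain makes no difference that can be read. The comparison with the ring-bearing compound is more informative, as 1,3-diaminopropyl in place of 3-aminocyclohexyl gives a number 15 percentage points lower from compound 1 to compound 3 (beyond the scatter) on the same aromatic carbon of the five-membered aromatic ring. Compound 1 therefore stands apart from both open-chain compounds, so an open chain falls short of the 3-aminocyclohexyl group here whether it carries chlorine or a second amine, although this rests on a single ring-bearing compound.

The compounds shown leave open whether the ring itself or the placing of its amine matters, which a cyclopentyl or piperidine group at this position could help to separate. They also leave open how a longer chain between the two amines, a hydroxyl group in place of either amine, or the opposite configuration of 1,3-diaminopropyl would read.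

Nothing available accounts for either step.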